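This account rests on a few compounds, and the source may have more. Where it says the series, first, only, none or still open, it means among the compounds named here.

Measured compounds in a functional assay on NCI-H292 cells (Homo sapiens) for inhibition, read by MTT assay, with a stated time of 72 h; a lower number here means a stronger inhibitor, a higher number a weaker inhibitor:
compound 1 `O=[N+]([O-])c1ccc(-c2csc(N/N=C/c3ccc(C(F)(F)F)cc3)n2)cc1` gives 7410 nM;
compound 2 `O=[N+]([O-])c1cccc(-c2csc(N/N=C/c3ccc(C(F)(F)F)cc3)n2)c1` gives 22800 nM;
compound 3 `FC(F)(F)c1ccc(/C=N/Nc2nc(-c3ccc(Cl)cc3Cl)cs2)cc1` gives 10400 nM.

Compound 3 has the second highest of the three numbers. One step, a 1.4-fold higher number from compound 1 to compound 3 (0.15 log units; within the scatter), lies within the scatter, whereas the other, a 2.2-fold lower number from compound 2 to compound 3 (0.34 log units; beyond the scatter), lies beyond it. Compound 4 `COc1ccc(-c2csc(N/N=C/c3ccc(C(F)(F)F)cc3)n2)cc1` has not been measured; it differs from compound 3 in one place: 4-methoxyphenyl in place of 2,4-dichlorophenyl on an aromatic carbon. Within the data shown here, no measured step involves a 4-methoxyphenyl group, so the expectation rests on the steps in which the aryl group at this same place was exchanged: a 3.1-fold higher number from compound 1 to compound 2 (0.49 log units; beyond the scatter), a 1.4-fold higher number from compound 1 to compound 3 (0.15 log units; within the scatter) and a 2.2-fold lower number from compound 2 to compound 3 (0.34 log units; beyond the scatter). Those exchanges moved this assay by modest amounts only, in both directions. For compound 4 a step of similar size is therefore expected, with no firm direction, so the estimate for compound 4 is 12000 nM with a range from 4000 nM to 40000 nM, which amounts to an expected step of a 1.2-fold higher number from compound 3 to compound 4 (0.06 log units; within the scatter).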

Compound 4, half-maximal inhibitory concentration: > 66100 nM
Compound 4: a limit, no number; the forecaster's own chance of this, stated with the estimate: 10%; middle value at least 5.5-fold (0.74 log units) away from the limit.
By their numbers in this assay, from the lowest: compounds 1 and 3 (each within the scatter of the next); then compound 2. At a limit, above all of these: compound 4.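

In this assay compound 4 gives a limit and not a number: the limit of > 66100 nM in this assay, at which 1 of the 4 values shown sits. The exchange at this position, on an aromatic carbon next to the ring nitrogen, is no longer modest in every case: the change to 4-methoxyphenyl gives an at least 6.3-fold higher number from compound 3 to compound 4 (0.80 log units; beyond the scatter), an at least 2.8-fold higher number from compound 2 to compound 4 (0.46 log units; beyond the scatter) and an at least 8.9-fold higher number from compound 1 to compound 4 (0.95 log units; beyond the scatter), all beyond the scatter. Compound 1, compound 2 and compound 3 therefore showed only part of the range at this position, and the heavy-atom count does not separate the groups, as 2,4-dichlorophenyl and 4-methoxyphenyl match in it.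

Going by these compounds, how far compound 4 lies past its limit stays open, so each of these steps has only a lower bound. Also open, on these data alone, is whether the methoxy group alone carries this shift, or whether a 4-aminophenyl or 4-methylphenyl group or a longer alkoxy chain would do the same.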